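The compounds below may be only part of what the source reports. "The series", "measured", "known", "first", "only" and "open" are said of these compounds alone.

In a functional assay on ACHN cells (Homo sapiens) for cytotoxicity, read by sulforhodamine B assay, with a stated time of 48 h, tested at 100 nM (a lower number here means a stronger effect, a higher number a weaker effect of the compound at the concentration tested), three compounds have been measured so far:

Compound 1 `COc1cc(C)cc(-c2nn(CC#N)cc2-c2ccc(-c3cccc(C(C)=O)c3)nc2)c1`: 93%
Compound 2 `Cc1cc(O)cc(-c2nn(CC#N)cc2-c2ccnc(-c3ccc(Oc4ccccc4)cc3)c2)c1`: 95%
Compound 3 `COc1cc(C)cc(-c2nn(CC#N)cc2-c2ccnc(-c3ccc(N(C)C)cc3)c2)c1`: 29%

Compound 3 stands lowest of the three numbers, that is, it shows the strongest effect at the tested concentration. Its nearest neighbour in the numbers is compound 1, whose higher value lies beyond the scatter, and compound 2 lies further away still, also beyond the scatter. Both higher values belong to compounds that carry a different group on the pyridine side, so the numbers alone do not separate the contribution of the 3-methoxy-5-methylphenyl group from that of the dimethylamino group.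

Compound 4 `Cc1cc(O)cc(-c2nn(CC#N)cc2-c2ccnc(-c3ccc(N(C)C)cc3)c2)c1` differs from compound 3 in one place: hydrogen in place of methyl on an oxygen on an aromatic ring

Among the compounds with values here, no pair of measured compounds differs in just this one place, so no measured step speaks to it directly. Within the data shown here, compound 2 carries the 3-hydroxy-5-methylphenyl group and gives a high number, but it differs from compound 3 in a second place too, so it shows only that the hydroxy group can sit in a weak compound. A modest step toward a higher number, not clearly beyond the scatter, is expected from compound 3 to compound 4: a number 16 percentage points higher from compound 3 to compound 4 (beyond the scatter). Compound 4 is therefore expected to give about 45%, most likely between 20% and 85%.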

Compound 4, a percentage reported as activity, at one concentration (the size of the read-out at that concentration, not a potency): 93%
Compound 4: middle estimate off by 48 percentage points, on the low side; the whole stated range lies below it.
By their numbers in this assay, from the lowest: compound 3; then compounds 1, 4 and 2 (each within the scatter of the next).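

In this assay, methoxy to hydroxy on the 3-methoxy-5-methylphenyl group, with the dimethylamino group kept, gives a number 64 percentage points higher from compound 3 to compound 4 (beyond the scatter), so this single methyl on an oxygen on an aromatic ring carries a large part of the effect seen for compound 3. With the hydroxy group in place, dimethylamino in place of phenoxy gives a number 2 percentage points lower from compound 2 to compound 4 (within the scatter), so in this pair the dimethylamino group does not bring back the effect that it accompanies in compound 3. Nothing measured here explains the large step.

Going by these compounds, it remains open whether an ethyl or a difluoromethyl group on that oxygen would behave like the methyl. Also open, on these data alone, is whether the methoxy group would give a similarly low number when paired with phenoxy instead of dimethylamino.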